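The source may hold more compounds than are shown below. What is called first, only, known or untested is meant among the compounds shown, and "the series" means these compounds.

Compound 1 `CCc1cc(S(=O)(=O)N2C[C@H](c3ccccc3)NC2=O)ccc1NC(=O)OC(C)C` carries an isopropyl carbamate on the shared core. Among the measured compounds shown here, in a functional assay on A549 cells (Homo sapiens) for cytotoxicity, read by MTT assay (a lower number here means a stronger inhibitor, a higher number a weaker inhibitor), compound 1 gives 60 nM, the only plain number among the three measured compounds. Compound 2 `Cc1cc(S(=O)(=O)N2C(=O)N[C@@H](c3ccccc3)C2C)ccc1NC(=O)c1ccc(N)cc1` reaches only a limit, giving > 10000 nM in this assay. Compound 3 `CCOC(=O)Nc1c(C)cc(S(=O)(=O)N2C[C@H](c3ccccc3)NC2=O)cc1C` likewise stops at a limit, giving > 10000 nM in this assay. Most of the picture is thus (the limit of > 10000 nM in this assay, at which 2 of the 3 values shown sit). Compound 4 `CCc1cc(S(=O)(=O)N2C[C@H](c3ccccc3)NC2=O)ccc1NC(=O)NC(C)C` is not yet measured; it differs from compound 1 by isopropylamino in place of isopropoxy on a carbonyl carbon. For the measured compounds named here, no measured pair shows this change, so the expectation is a small step within the usual scatter, as a 1.7-fold higher number from compound 1 to compound 4 (0.22 log units; within the scatter) is estimated. Compound 4 is accordingly expected at 100 nM, with a likely range from 20 nM to 600 nM.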

Compound 4, half-maximal inhibitory concentration: 100 nM
Compound 4: the middle estimate sits on the measured number at the digits printed; measured number inside the range.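

Isopropylamino brings a hydrogen-bond donor where isopropoxy brought an acceptor, yet a 1.7-fold higher number from compound 1 to compound 4 (0.22 log units; within the scatter) in this assay leaves the two compounds indistinguishable. Among the compounds shown here, this is the first step here read between two plain numbers, and it shows that this carbonyl position keeps its activity through this swap of oxygen for nitrogen. Nothing shown gives a cause for this step.

As far as these compounds go, a longer chain or a ring amine such as morpholine on this carbonyl carbon remains open. So does how far this single swap holds on other cores.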